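A few compounds are considered here, and "the series" means these few. Any claim that something is new, unique, unknown or untested is made for them only; others in the source may bear on it.

Of the compounds shown here, three built on the same core have been measured so far. Compound 1, `N=C(N)c1ccc(-c2ccc(-c3cc(Cl)cc(Cl)c3)s2)cc1`, gives 1600 nM in a functional assay on SK-MEL-5 cells (Homo sapiens) for inhibition, read by sulforhodamine B assay, with a stated time of 48 h; a lower number here means a stronger inhibitor of growth, a higher number a weaker inhibitor of growth. Compound 2, `N=C(N)c1ccc(-c2ccc(-c3ccc(F)cc3)s2)cc1`, gives 1600 nM in this assay, and compound 3, `COc1cc(OC)cc(-c2ccc(-c3ccc(C(=N)N)cc3)s2)c1`, gives 1810 nM in this assay. On these numbers compound 2 stands level with compound 1 at the digits shown, and its distance from compound 3 lies within the usual scatter, so the three cannot be told apart. Compound 4, `N=C(N)c1ccc(-c2ccc(-c3ccc(Cl)cc3)s2)cc1`, has not yet been tested. It differs from compound 2 in one place: chloro in place of fluoro on an aromatic carbon, so that a 4-fluorophenyl becomes a 4-chlorophenyl. Among the measured compounds shown here, no pair among the measured compounds isolates this single change, so nothing in the data says how large its effect is. In this assay the expected change is a 1.1-fold lower number from compound 2 to compound 4 (0.03 log units; within the scatter), no more than the scatter in either direction. Compound 4 is therefore estimated at 1500 nM, within a range from 700 nM to 3200 nM.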

Compound 4, concentration for 50% growth inhibition: 204 nM
Beside the measured number, compound 4's estimate is 7.4-fold (0.87 log units) above it, outside the stated range (below it).
By their numbers in this assay, from the lowest: compound 4; then compounds 1, 2 and 3 (each within the scatter of the next).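

In this assay, replacing the fluoro of compound 2 with chloro gives a 7.8-fold lower number from compound 2 to compound 4 (0.89 log units; beyond the scatter) and this is the only pair shown that isolates a single change. The step lies beyond the scatter, so the halogen at this position, para to a large group, makes a clear difference to the number, which the three earlier compounds could not show. The change is small when counted: one heavy atom is exchanged for another, with no ring, net charge, hydrogen-bond donor or hydrogen-bond acceptor entering or leaving, and no measurement here accounts for the size of the step.

The compounds shown leave open what bromo, methyl, methoxy, an amine or a carboxylic acid would do at this position. Among the compounds shown here, they also leave open whether the same step would appear with other groups elsewhere on the shared core, as no second pair repeats this change.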